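Replacing a methylphenyl group with a methoxy-bearing chain

The compounds below may be only part of what the source reports. "The series", "measured", "known", "first", "only" and "open" are said of these compounds alone.

Compound 1 `Cc1cccc([C@@H](O)C(=O)N2N=CC[C@H]2C(=O)NCc2cc(Cl)ccc2-n2cnnn2)c1`: 830 nM
Compound 2 `CCCC[C@@H](O)C(=O)N1C[C@H]2C[C@H]2[C@H]1C(=O)NCc1cc(Cl)ccc1-n1cnnn1`: 750 nM
Compound 3 `CC(C)(C)[C@@H](O)C(=O)N1CSC[C@H]1C(=O)NCc1cc(Cl)ccc1-n1cnnn1`: 1200 nM

Of the compounds shown here, three sharing the same chlorophenyl-tetrazole amide tail have been tested in a functional assay on a cell-free system (plasma, Homo sapiens), with a stated time of 3 min; on this read-out higher numbers stand for weaker inhibition and lower numbers for stronger inhibition. Compound 1 stands second highest of the three numbers; its nearest neighbour is compound 2, and its furthest is compound 3, yet both of those gaps lie within the usual scatter, so no ordering among the three can be claimed.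

The step to compound 4 `COC(C)(C)[C@@H](O)C(=O)N1N=CC[C@H]1C(=O)NCc1cc(Cl)ccc1-n1cnnn1` changes the group on the hydroxyl-bearing carbon: 1-methoxy-1-methylethyl in place of 3-methylphenyl on a saturated chain carbon bound to a carbonyl carbon and an oxygen on a saturated carbon. The other two compounds carry saturated groups at that same carbon, and their values sit close to that of compound 1, which suggests that an aromatic ring is not required there.

Compound 4 is therefore expected to give about 1000 nM in this assay, a step of a 1.2-fold higher number from compound 1 to compound 4 (0.08 log units; within the scatter) that is estimated to stay within the scatter, with a plausible range from 400 nM to 2500 nM.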

Compound 4, half-maximal inhibitory concentration: 3700 nM
Compound 4: the middle estimate sits 3.7-fold (0.57 log units) below what was measured; the whole stated range lies below it.
By their numbers in this assay, from the lowest: compounds 2, 1 and 3 (each within the scatter of the next); then compound 4.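

In this assay, the change on the saturated chain carbon bound to a carbonyl carbon and an oxygen on a saturated carbon gives a 4.5-fold higher number from compound 1 to compound 4 (0.65 log units; beyond the scatter). With the core of compound 1 held fixed, this position therefore responds to its group, and 1-methoxy-1-methylethyl does not match 3-methylphenyl there, which compound 2 and compound 3 could not show, since each differs from compound 1 in more than one place. Nothing measured here accounts for this step.

The change removes an aromatic ring and brings in an oxygen together, so the compounds shown do not separate the two. Going by these compounds, how a cyclohexyl group would read on this same core remains open, as does whether the step follows the loss of the ring or the arrival of the methoxy group.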